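A few compounds are considered here, and "the series" means these few. Any claim that something is new, unique, unknown or untested is made for them only; others in the source may bear on it.

In a functional assay on B16-F10 cells (Mus musculus) for antiproliferative activity, read by MTT assay, with a stated time of 72 h (on this read-out lower numbers stand for stronger inhibition and higher numbers for weaker inhibition), compound 1 `O=C1Nc2c(F)cccc2/C1=C1/Nc2ccccc2C1=O` gives 16300 nM, a measured number that shows this kind of compound can slow cell growth. Compound 2 `O=C1Nc2ccccc2/C1=C1/Cc2ccccc2C1=O` reads > 100000 nM in this assay, and that entry is a limit of the assay and not a number.

Compound 3 `O=C1Nc2ccc(Br)cc2/C1=C1/Cc2ccccc2C1=O` is compound 2 with one change: bromo in place of hydrogen on an aromatic carbon. Going by the values given here, no measured pair of compounds shows what this change does. The expectation is therefore only a moderate shift toward stronger inhibition in this assay, meaning a lower number, and the result may again be only a limit. The expected size of the change is an at least 1.6-fold lower number from compound 2 to compound 3 (0.22 log units; that floor lies within the scatter). For compound 3 the estimated value is 60000 nM, with an expected range of 15000 nM to 150000 nM.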

Compound 3, half-maximal inhibitory concentration: 69100 nM
For compound 3 the middle estimate is 1.2-fold (0.06 log units) below the measured one; measured number inside the range.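

In this assay compound 3 gives 69100 nM, so bromo on this six-membered aromatic ring of carbon only yields a measured number where the parent compound gave none. The change amounts to an at least 1.4-fold lower number from compound 2 to compound 3 (0.16 log units; that floor lies within the scatter), which means this pair alone does not establish a real gain in inhibition. The size of the step stays a floor, because the entry for compound 2 is a limit of the assay and not a number: the limit of > 100000 nM in this assay, at which 1 of the 3 values shown sits.

The compounds shown leave open whether another group on this same carbon, such as chloro, methoxy or an amine, would lower the number further. Also open, from the compounds shown here alone, is whether bromo here would act in the same way on the core of compound 1, which differs from compound 3 in more than one place.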